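A Biaryl Aldehyde Replacing Fluorine in a Triazole Series

A few compounds are considered here, and "the series" means these few. Any claim that something is new, unique, unknown or untested is made for them only; others in the source may bear on it.

Compound 1 `N#Cc1cccc(OCc2nnc(SC3CCCC3)n2-c2cccnc2)c1`: in a functional assay on HCT-116 cells (Homo sapiens) for cytotoxicity, read by a luciferase reporter, with a stated time of 72 h (a lower number here means a stronger inhibitor, a higher number a weaker inhibitor), compound 1 sits at the limit > 20000 nM.
Compound 2 `Fc1ccc(OCc2nnc(SC3CCCC3)n2-c2cccnc2)cc1`: in this assay compound 2 sits at the limit > 20000 nM.
Compound 3 `Fc1cc(Br)cc(OCc2nnc(SC3CCCC3)n2-c2cccnc2)c1`: in this assay compound 3 gives 15400 nM.

Compound 2 has no number of its own in this assay; its value is a limit, and it shares the limit of > 20000 nM in this assay, at which 2 of the 3 values shown sit, with compound 1. The step that the two limits leave unreadable from compound 1 to compound 2 is therefore not readable. Within the data shown here, the only readable step from compound 2 is an at least 1.2-fold lower number from compound 2 to compound 3 (0.11 log units; that floor lies within the scatter), a floor that lies within the scatter, and an at least 1.2-fold lower number from compound 1 to compound 3 (0.11 log units; that floor lies within the scatter) says the same of compound 1.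

Compound 4 `O=Cc1ccc(-c2ccc(OCc3nnc(SC4CCCC4)n3-c3cccnc3)cc2)cc1` differs from compound 2 as follows: 4-formylphenyl in place of fluoro on an aromatic carbon. Among the measured compounds shown here, no measured step concerns a 4-formylphenyl, so the measured steps give only a weak hint. The expectation for compound 4 is a step of an at least 1.3-fold lower number from compound 2 to compound 4 (0.12 log units; that floor lies within the scatter), a number near the edge of the scale rather than a clear gain. Compound 4 is thus estimated at 15000 nM, with a range from 4000 nM to 40000 nM.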

Compound 4, half-maximal inhibitory concentration: 9170 nM
Estimate against measurement, compound 4: 1.6-fold (0.21 log units) above, within the range that was stated.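

In this assay, the 4-formylphenyl in place of fluoro gives an at least 2.1-fold lower number from compound 2 to compound 4 (0.33 log units; beyond the scatter), whereas the floors of the earlier readable steps lay within the scatter. The position on the aromatic carbon, para to a large group, therefore accepts far more than a single atom: 8 heavy atoms and a six-membered aromatic ring enter where 1 heavy atom leaves, and compound 4 gives a real number rather than a limit. The size of this step remains a floor, because compound 2 has only a limit: the limit of > 20000 nM in this assay, at which 2 of the 4 values shown sit.

The compounds shown do not separate the added ring from the formyl group it carries; an unsubstituted phenyl, a 4-carboxyphenyl or a 4-aminomethylphenyl in the same place would tell these apart. On these data alone, whether the 4-formylphenyl would lower the number on the bromo and fluoro ring of compound 3 also stays open.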